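A few compounds are considered here, and "the series" means these few. Any claim that something is new, unique, unknown or untested is made for them only; others in the source may bear on it.

In a series of aryl sulfonamide ureas, compound 1 `Cc1ccccc1NS(=O)(=O)c1cccc(NC(=O)NCCCCl)c1` was tested in a functional assay on HT-29 cells (Homo sapiens) for cytotoxicity, read by sulforhodamine B assay, with a stated time of 48 h (on this read-out higher numbers stand for weaker inhibition and lower numbers for stronger inhibition), where compound 1 gave 42000 nM. Compound 2 `CCc1ccccc1NS(=O)(=O)c1cccc(NC(=O)NCCCCl)c1` carries the same chain, and in this assay compound 2 gave 96000 nM. The step of a 2.3-fold higher number from compound 1 to compound 2 (0.36 log units; beyond the scatter) corresponds to the change (methyl in place of hydrogen on a saturated chain carbon bound to an aromatic carbon). Compound 3 `Cc1ccccc1NS(=O)(=O)c1ccc(NC(=O)NCCCCl)cc1` has the same atoms as compound 1 joined differently; the difference between the two cores is not broken down here. In this assay compound 3 gave 64000 nM, a number within the usual scatter of the numbers for both compound 1 and compound 2. Compound 4 `CCc1ccccc1NS(=O)(=O)c1ccc(NC(=O)NCCCCl)cc1` has not yet been measured. It differs from compound 3 by methyl in place of hydrogen on a saturated chain carbon bound to an aromatic carbon, the same change, at the same place, that was already made from compound 1 to compound 2. Because the earlier step of a 2.3-fold higher number from compound 1 to compound 2 (0.36 log units; beyond the scatter) was modest, the step of a 1.9-fold higher number from compound 3 to compound 4 (0.27 log units; within the scatter) is expected to be of similar size, within the range of the one observation available. The value of compound 4 in this assay is therefore estimated at 120000 nM, with a plausible range from 55000 nM to 260000 nM.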

Compound 4, half-maximal inhibitory concentration: > 200000 nM
Compound 4 gave a limit, no number; the forecaster's own chance of this, stated with the estimate: 25%; middle value at least 1.6-fold (0.22 log units) from the limit.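

In this assay compound 4 gave > 200000 nM, which is a limit of the assay and not a number. On the second core, the change from 2-methylphenyl to 2-ethylphenyl gave an at least 3.1-fold higher number from compound 3 to compound 4 (0.49 log units; beyond the scatter), so the step lies beyond the scatter and points the same way as the step on the first core. This shows that the change carried over in direction between these two pairs, but it does not show whether its size carried over, and two pairs set no rule for the whole series: the same change on two cores in this assay, a 2.3-fold higher number (0.36 log units; beyond the scatter) from compound 1 to compound 2 and an at least 3.1-fold higher number (0.49 log units; beyond the scatter) from compound 3 to compound 4; the limit leaves it open whether they differ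

The compounds shown leave open what an exact value for compound 4 would be, and whether a propyl or a methoxy group in place of the ethyl would move the number further on either core. They also leave open whether the same change would behave alike if an amine or a hydroxyl group replaced the chlorine on the chain.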